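The source may report more compounds than this note shows. Statements on the series, on what has been measured and on what is new or still open speak of the compounds shown alone.

Within the data shown here, in a functional assay on MDA-MB-231 cells (Homo sapiens) for antiproliferative activity, read by MTT assay, with a stated time of 48 h (a lower number here means a stronger inhibitor, a higher number a weaker inhibitor), compound 1 `COc1ccc(N(C)c2ccnc(Cl)n2)cc1` gives 2820 nM, the higher of the two numbers so far, and compound 2 `COc1ccc(N(C)c2ccnc(Cl)n2)cc1F` gives 1280 nM. The step in question leads to compound 3 `COc1ccc(N(C)c2ccnc(Cl)n2)cc1OCCCCBr`: 4-bromobutoxy in place of hydrogen on an aromatic carbon. This places 4-bromobutoxy in place of hydrogen on an aromatic carbon, ortho to a methoxy group. Among the measured compounds shown here, only one measured step bears on this, fluoro in place of hydrogen on an aromatic carbon, which gave a 2.2-fold lower number from compound 1 to compound 2 (0.34 log units; beyond the scatter), a modest change. For the measured compounds named here, no measured compound carries a chain of this kind, and that single step is a loose guide. A modest step towards a lower number is expected, although a step within the scatter or in the opposite direction remains possible. For compound 3 the expected value is 1600 nM, with an estimated range of 500 nM to 5000 nM. The estimated step is a 1.8-fold lower number from compound 1 to compound 3 (0.25 log units; within the scatter).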

Compound 3, half-maximal inhibitory concentration: 992 nM
The estimate for compound 3 lay 1.6-fold (0.21 log units) above the measured number; measured number inside the range.
By their numbers in this assay, from the lowest: compounds 3 and 2 (each within the scatter of the next); then compound 1.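

In this assay, the aromatic carbon ortho to a methoxy group also takes a group much larger than fluoro: 4-bromobutoxy, a chain with no ring, gives a 2.8-fold lower number from compound 1 to compound 3 (0.45 log units; beyond the scatter). Replacing fluoro with this chain gives a 1.3-fold lower number from compound 2 to compound 3 (0.11 log units; within the scatter), so the two substituents cannot be told apart at this position. Across these three compounds, both substituents give a lower number than hydrogen, and none of the three goes against this, though the pattern rests on these compounds alone.

From the compounds shown here alone, whether the step depends on the length of the chain or on its terminal bromine stays open; a plain butoxy group, a shorter bromoalkoxy chain, or a chain ending in an amine or a carboxylic acid would separate these. No measured property is available to account for the result.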